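The compounds below may be only part of what the source reports. "The series", "measured", "known", "first", "only" and "open" are said of these compounds alone.

Of the compounds shown here, three with a shared core have been measured in an ADME assay on microsomes from liver (Homo sapiens) for metabolic stability, tested at 2.5 uM; on this read-out lower numbers stand for slow clearance and higher numbers for fast clearance. Compound 1 `O=S(=O)(c1ccc(F)c(Cl)c1)c1cnc2cc(F)ccc2c1-c1ccc(Cl)cc1` gives 0.39 mL/min. Compound 2 `O=S(=O)(c1ccc(F)c(Cl)c1)c1cnc2cc(F)ccc2c1-c1ccc(F)cc1` gives 0.69 mL/min, and compound 3 `O=S(=O)(c1ccc(F)c(Cl)c1)c1cnc2cc(F)ccc2c1-c1ccccc1F` gives 1.07 mL/min. Compound 2 stands second highest of the three: its neighbour is compound 3, and the gap a 1.6-fold higher number from compound 2 to compound 3 (0.19 log units; within the scatter) lies within the scatter, as does the gap a 1.8-fold higher number from compound 1 to compound 2 (0.25 log units; within the scatter) on the other side. Within the data shown here, only the pair of compound 1 and compound 3 differ beyond the scatter, by a 2.7-fold higher number from compound 1 to compound 3 (0.44 log units; beyond the scatter).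

Compound 4 `COc1ccc(S(=O)(=O)c2cnc3cc(F)ccc3c2-c2ccc(F)cc2)cc1` is the next compound, not yet measured. It differs from compound 2 in one place: 4-methoxyphenyl in place of 3-chloro-4-fluorophenyl on a sulfonyl sulfur. Among the measured compounds shown here, every measured step so far changed the other aromatic ring, the one attached to the core carbon, and none touched the ring on the sulfonyl sulfur. So none of the three steps bears on this change, and the measured numbers give no direct guide to its direction or size. The expectation for compound 4 in this assay therefore rests on the narrow spread of the three values and stays close to compound 2, with a wide margin in both directions, as a step of a 1.4-fold higher number from compound 2 to compound 4 (0.16 log units; within the scatter). Compound 4 is estimated at 1 mL/min, between 0.35 mL/min and 2.8 mL/min.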

Compound 4, intrinsic clearance in a liver preparation (reported as CLH), per the amount of preparation that the assay uses: 1.71 mL/min
Beside the measured number, compound 4's estimate is 1.7-fold (0.23 log units) below it; measured number inside the range.
By their numbers in this assay, from the lowest: compounds 1, 2, 3 and 4 (each within the scatter of the next, the first and the last beyond it).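

In this assay, among these compounds, the change on the sulfonyl sulfur, 4-methoxyphenyl in place of 3-chloro-4-fluorophenyl, gives a 2.5-fold higher number from compound 2 to compound 4 (0.39 log units; beyond the scatter) and so points toward faster clearance, showing that the read-out responds to this ring and not only to the ring on the core carbon that the earlier steps changed. This single swap alters several things at once: a chlorine and a fluorine leave, while a methoxy group enters and brings the one hydrogen-bond acceptor counted for the new ring, so the step cannot show which of these differences matters. No measurement in hand explains why the number rises.

Still open, on these data alone, is how clearance would respond to other groups on this ring, such as an amine, a nitrile or a longer ether chain, or to a ring that keeps only the chlorine or only the fluorine. Also open, as far as these compounds go, is whether the same swap would give a similar step with the 4-chlorophenyl of compound 1 or the 2-fluorophenyl of compound 3 on the core carbon.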